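Swapping the Ether Tail on a Shared Core

The source may hold more compounds than are shown below. What is called first, only, known or untested is meant among the compounds shown, and "the series" means these compounds.

Of the compounds shown here, three built on one shared core have been measured in a functional assay on A549 cells (Homo sapiens) for antiproliferative activity, read by MTT assay, with a stated time of 12 h; on this read-out lower numbers stand for stronger inhibition and higher numbers for weaker inhibition. Compound 1 `COc1cc(OC)c2c(=O)cc(/C=C/c3ccc([N+](=O)[O-])cc3)oc2c1` gives 19700 nM. Compound 2 `COc1cc(OC)c2c(=O)cc(/C=C/c3ccc(OCC4CC4)cc3)oc2c1` gives 20900 nM. Compound 3 `COc1cc(OC)c2c(=O)cc(/C=C/c3ccc(F)cc3)oc2c1` gives 18600 nM. Compound 2 sits alongside both neighbours rather than apart from them, as a 1.1-fold higher number from compound 1 to compound 2 (0.03 log units; within the scatter) and a 1.1-fold lower number from compound 2 to compound 3 (0.05 log units; within the scatter) show, and a 1.1-fold lower number from compound 1 to compound 3 (0.02 log units; within the scatter) closes the triangle in the same way.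

Compound 4 `COc1cc(OC)c2c(=O)cc(/C=C/c3ccc(OC(F)(F)F)cc3)oc2c1` has not yet been measured. It differs from compound 2 in one place: trifluoromethyl in place of cyclopropylmethyl on an oxygen on an aromatic ring. The two exchanges already seen at the same point of the structure, a 1.1-fold higher number from compound 1 to compound 2 (0.03 log units; within the scatter) and a 1.1-fold lower number from compound 2 to compound 3 (0.05 log units; within the scatter), both stayed inside the scatter, so a third exchange there is expected to leave the number close to where compound 2 stands, with no step beyond the scatter in either direction. Compound 4 is therefore estimated at 20000 nM, with a range from 10000 nM to 40000 nM. That estimate means an expected step of a 1.0-fold lower number from compound 2 to compound 4 (0.02 log units; within the scatter).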

Compound 4, half-maximal inhibitory concentration: 24200 nM
The estimate for compound 4 lay 1.2-fold (0.08 log units) below the measured number, and the stated range covers the measured number.
By their numbers in this assay, from the lowest: compounds 3, 1, 2 and 4 (each within the scatter of the next).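

In this assay trifluoromethoxy on the aromatic carbon stays level with every group seen there before, since a 1.2-fold higher number from compound 2 to compound 4 (0.06 log units; within the scatter) and a 1.3-fold higher number from compound 3 to compound 4 (0.11 log units; within the scatter) and a 1.2-fold higher number from compound 1 to compound 4 (0.09 log units; within the scatter) all lie within the scatter. Swapping cyclopropylmethyl, with its three-membered carbon ring, for the ring-free trifluoromethyl on the same oxygen therefore gives a number that cannot be told apart from that of compound 2, so nitro, fluoro, cyclopropylmethoxy and trifluoromethoxy are now four groups that this read-out does not separate. Nothing available here accounts for this flat result.

Going by these compounds, whether any group at this position can move the number beyond the scatter stays open, for instance an amine or a carboxylic acid. Changes elsewhere on the shared core also remain untested by these four compounds.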